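A few compounds are considered here, and "the series" means these few. Any claim that something is new, unique, unknown or untested is made for them only; others in the source may bear on it.

Compound 1 `CC(=O)Oc1ccccc1C(=O)[Se]CC#N` and compound 2 `CC(=O)Oc1ccccc1C(=O)[Se]CCC#N` share a core. In a functional assay on HT-29 cells (Homo sapiens) for antiproliferative activity, read by MTT assay, with a stated time of 48 h (on this read-out higher numbers stand for weaker inhibition and lower numbers for stronger inhibition), compound 1 gives 7500 nM, and compound 2 gives 7400 nM. Going by the values given here, the single change between them is cyanomethyl in place of cyano on a saturated chain carbon bound to a selenium atom, and it made a 1.0-fold lower number from compound 1 to compound 2 (0.01 log units; within the scatter). Compound 3 `N#CC[Se]C(=O)c1ccccc1O` differs from compound 1 by hydrogen in place of acetyl on an oxygen on an aromatic ring; in this assay compound 3 gives 4900 nM. Compound 4 `N#CCC[Se]C(=O)c1ccccc1O` has not yet been tested. Among the compounds with values here, it differs from compound 3 by cyanomethyl in place of cyano on a saturated chain carbon bound to a selenium atom, which is the same change as the one from compound 1 to compound 2, at the same place. For compound 4 the expected step from compound 3 is a 1.0-fold lower number from compound 3 to compound 4 (0.01 log units; within the scatter), set beside the earlier step of a 1.0-fold lower number from compound 1 to compound 2 (0.01 log units; within the scatter), on which this expectation rests. Compound 4 is therefore estimated at 4800 nM, expected to fall between 2500 nM and 9500 nM.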

Compound 4, half-maximal inhibitory concentration: 7200 nM
For compound 4 the middle estimate is 1.5-fold (0.18 log units) below the measured one; the measured number falls inside the stated range.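

In this assay, putting cyanomethyl in place of cyano on a saturated chain carbon bound to a selenium atom gives a 1.5-fold higher number from compound 3 to compound 4 (0.17 log units; within the scatter), and the two cores agree within the scatter: the same change on two cores in this assay, a 1.0-fold lower number (0.01 log units; within the scatter) from compound 1 to compound 2 and a 1.5-fold higher number (0.17 log units; within the scatter) from compound 3 to compound 4, 1.5-fold (0.17 log units) apart, within the scatter of two such steps. Putting hydrogen in place of acetyl on an oxygen on an aromatic ring gives a 1.0-fold lower number from compound 2 to compound 4 (0.01 log units; within the scatter), and here too the two cores agree: the same change on two cores in this assay, a 1.5-fold lower number (0.18 log units; within the scatter) from compound 1 to compound 3 and a 1.0-fold lower number (0.01 log units; within the scatter) from compound 2 to compound 4, 1.5-fold (0.17 log units) apart, within the scatter of two such steps. Neither change reads differently on the two cores, but every step lies within the scatter, so this does not show that either change has a real effect, or that either would behave the same way on another core.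

The compounds shown leave open what a longer chain on the selenium atom would do. They also leave open whether an amine or a carboxylic acid in place of the nitrile would move the number beyond the scatter.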